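The source may report more compounds than this note shows. Statements on the series, on what has been measured and on what is new or still open speak of the compounds shown alone.

In an ADME assay on Vero cells (Chlorocebus sabaeus) for cytotoxicity, read by CellTiter-Glo, with a stated time of 72 h (a higher number here means that more compound is tolerated, a lower number that less compound is tolerated), three compounds have been read so far. Compound 1 `CC(=O)Nc1cc(/C=C\c2ccc([N+](=O)[O-])o2)ns1` gives > 50 ug/mL, which is a limit of the assay. Compound 2 `COCCNC(=O)c1ccc2c(c1)[n+]([O-])c(C(C)=O)c(C)[n+]2[O-]` gives > 16 ug/mL, which is also a limit. Going by the values given here, compound 3 `CC(C)(C)Nc1n[n+]([O-])c2ccccc2[n+]1[O-]` gives 8 ug/mL, the only actual number in the set. Compound 4 `COCC(C)Nc1n[n+]([O-])c2ccccc2[n+]1[O-]` differs from compound 3 in one place: 1-(methoxymethyl)ethyl in place of tert-butyl on a nitrogen on an aromatic ring. In words, 1-(methoxymethyl)ethyl stands in place of tert-butyl on a nitrogen on an aromatic ring. Among the compounds with values here, no measured pair differs in a single place. In this assay, no change beyond the usual scatter is expected, in either direction. The expected step, a 1.3-fold higher number from compound 3 to compound 4 (0.10 log units; within the scatter), is an estimate only. Compound 4 is estimated at 10 ug/mL, with an expected range of 4 ug/mL to 25 ug/mL.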

Compound 4, half-maximal cytotoxic concentration: > 50 ug/mL
Compound 4 gave a limit, no number; the forecaster's own chance of this, stated with the estimate: 15%; middle value at least 5.0-fold (0.69 log units) away from the limit.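

In this assay, going by these compounds alone, the group on a nitrogen on an aromatic ring turns out to matter: 1-(methoxymethyl)ethyl in place of tert-butyl gives an at least 6.2-fold higher number from compound 3 to compound 4 (0.79 log units; beyond the scatter) and provides the first single-place step. Because compound 4 reads as a limit, the step has a floor but no ceiling: the limit of > 50 ug/mL in this assay, at which 2 of the 4 values shown sit.

On these data alone, whether the step comes from the oxygen of the new group or from the removal of tert-butyl stays open. An isopropyl or a 2-methoxyethyl group on the same nitrogen would separate the two.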